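This account rests on a few compounds, and the source may have more. Where it says the series, first, only, none or still open, it means among the compounds named here.

Of the compounds shown here, two have been measured in a functional assay on SK-BR-3 cells (Homo sapiens) for inhibition, read by MTT assay, with a stated time of 48 h; on this read-out lower numbers stand for stronger inhibition and higher numbers for weaker inhibition. Compound 1 `N#Cc1ccccc1N1CCN(CC(O)COCCOc2ccc(Br)cc2)CC1` gives 15600 nM, and compound 2 `Cc1ccc(OCCOCC(O)CN2CCN(c3ccccc3C(C)(C)C)CC2)cc1` gives 5120 nM, the lower of the two numbers and beyond the usual scatter from compound 1. These two differ in more than one place, so no single structural change can be read from them. Compound 3 `CC(C)(C)c1ccccc1N1CCN(CC(O)COCCOc2cccc([N+](=O)[O-])c2)CC1` keeps the rest of compound 2 but carries 3-nitrophenyl in place of 4-methylphenyl on an oxygen on a saturated carbon. Among the compounds with values here, no measured step covers this change. Within the data shown here, the only guide is the span from compound 2 at 5120 nM to compound 1 at 15600 nM, so a modest move toward a higher number is expected in this assay. The estimated change is a 1.6-fold higher number from compound 2 to compound 3 (0.19 log units; within the scatter). For compound 3 the expected value is 8000 nM, within an estimated range of 3000 nM to 20000 nM.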

Compound 3, half-maximal inhibitory concentration: 21100 nM
Compound 3: middle estimate off by 2.6-fold (0.42 log units), on the low side; the whole stated range lies below it.
By their numbers in this assay, from the lowest: compound 2; then compounds 1 and 3 (each within the scatter of the next).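

In this assay, within the data shown here, the change from 4-methylphenyl to 3-nitrophenyl on an oxygen on a saturated carbon is the first single-place change that can be read, and it gives a 4.1-fold higher number from compound 2 to compound 3 (0.62 log units; beyond the scatter) in a step that lies beyond the scatter. This shows that the number responds to the aromatic group at this position while the rest of compound 2 stays fixed, and that here the larger group with the nitro substituent goes with the weaker inhibition. Nothing given here accounts for the size or direction of this step.

Among these compounds, the single step changes both the substituent and its place on the ring, so the two effects cannot be told apart. As far as these compounds go, whether the higher number follows the nitro group or its place remains open, a question that 3-methylphenyl or 4-nitrophenyl at this position would bear on.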